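The source may hold more compounds than are shown below. What is called first, only, known or untested is meant among the compounds shown, and "the series" means these compounds.

Compound 1 `Cc1cc(Nc2cc(N3CCN(C)CC3)nc(Nc3ccc(S(N)(=O)=O)cc3)n2)n[nH]1`: 213 nM
Compound 2 `COc1cccc(Nc2nc(Nc3cc(C)[nH]n3)cc(N3CCN(C)CC3)n2)c1`: 397 nM

Within the data shown here, in a functional assay on HL-60 cells (Homo sapiens) for antiproliferative activity, read by CCK-8 assay, with a stated time of 72 h (on this read-out lower numbers stand for stronger inhibition and higher numbers for weaker inhibition), compound 2 lies within the usual scatter of compound 1, the only other compound measured. Compound 3 `Cc1cc(Nc2cc(N3CCN(C)CC3)nc(Nc3ccc(C#N)cc3)n2)n[nH]1` keeps the shared core and carries 4-cyanophenyl in place of 3-methoxyphenyl on a nitrogen on an aromatic ring. One measured step changed the group at this place, a 1.9-fold higher number from compound 1 to compound 2 (0.27 log units; within the scatter). Among the measured compounds shown here, with only that small step to go on, no change beyond the scatter is expected in this assay. The estimated step is a 1.4-fold lower number from compound 2 to compound 3 (0.15 log units; within the scatter). For compound 3 the expected value is 280 nM, with an estimated range of 100 nM to 800 nM.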

Compound 3, half-maximal inhibitory concentration: 21.8 nM
Estimate against measurement, compound 3: 13-fold (1.11 log units) above; the measured number lies below the stated range.
By their numbers in this assay, from the lowest: compound 3; then compounds 1 and 2 (each within the scatter of the next).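

Swapping the group on this nitrogen can shift the number far more than the first step suggested: 3-methoxyphenyl to 4-cyanophenyl gives an 18-fold lower number from compound 2 to compound 3 (1.26 log units; beyond the scatter). Cyano in place of sulfamoyl gives a 9.8-fold lower number from compound 1 to compound 3 (0.99 log units; beyond the scatter), so 4-cyanophenyl stands clearly apart from two groups that lay within the scatter of each other. No measurement here accounts for this gain. On these data alone, whether it depends on the nitrile itself remains open. So does how a carboxylic acid, a primary amide or a chlorine at that ring place would compare.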